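Swapping Fluorine for Chlorine on a Piperazine Arene

The source may hold more compounds than are shown below. What is called first, only, known or untested is meant among the compounds shown, and "the series" means these compounds.

Compound 1 `O=c1oc2cccnc2n1CN1CCN(c2cccc(C(F)(F)F)c2)CC1`, compound 2 `O=c1oc2cccnc2n1CCN1CCN(c2ccc(F)cc2)CC1`, compound 3 `O=c1oc2cccnc2n1CCN1CCCCC1` and compound 4 `O=c1oc2cccnc2n1CCN1CCN(c2ccc(Cl)cc2)CC1` share one core and differ only in the side chain attached to it. In a functional assay on the whole organism with Mus musculus as the target (a higher number here means that more compound is needed for the effect, a lower number that less compound is needed), compound 1 gives 3.6 mg/kg. In this assay compound 2 gives 41.3 mg/kg, the higher of the two numbers, and its gap to compound 1 lies beyond the usual scatter. In this assay compound 3 gives only a limit, > 25 mg/kg, not a number. Compound 4 has not yet been measured; it differs from compound 2 by chloro in place of fluoro on an aromatic carbon. Within the data shown here, no measured pair tests this change, so the expected step of a 1.7-fold lower number from compound 2 to compound 4 (0.22 log units; within the scatter) is small, toward a lower number, and may stay within the scatter. Compound 4 is expected to give about 25 mg/kg, between 8 mg/kg and 80 mg/kg.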

Compound 4, dose for half-maximal effect: > 50 mg/kg
Compound 4: a limit, no number; the forecaster's own chance of this, stated with the estimate: 20%; middle value at least 2.0-fold (0.30 log units) away from the limit.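

In this assay compound 4 gives > 50 mg/kg, which is a limit and not a number. Going from 4-fluorophenyl to 4-chlorophenyl gives an at least 1.2-fold higher number from compound 2 to compound 4 (0.08 log units; that floor lies within the scatter), so this first direct test at this position shows no sign of the lower number expected for chloro. The real size of the step cannot be read because only a floor is available: the limit of > 50 mg/kg in this assay, at which 1 of the 4 values shown sits.

As far as these compounds go, whether a methoxy group or an amine at this same place on the aromatic ring would lower the number stays open. So does whether a number for compound 4 would lie beyond the scatter.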